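The source may hold more compounds than are shown below. What is called first, only, known or untested is meant among the compounds shown, and "the series" means these compounds.

Measured compounds:

Compound 1, `Nc1cccc(Cn2cc(CCCCC[C@@H]3SC[C@@H]4NC(=O)N[C@@H]43)nn2)c1`: in an assay on isolated protein for inhibition of biotin--protein ligase (Homo sapiens), read by scintillation counting, with a stated time of 10 min (a lower number here means a stronger inhibitor, a higher number a weaker inhibitor), compound 1 gives > 16000 nM, which is a limit of the assay rather than a number.

Compound 2, `Cc1cccc(Cn2cc(CCCCC[C@@H]3SC[C@@H]4NC(=O)N[C@@H]43)nn2)c1`: compound 2 gives > 16000 nM, again a limit of the assay.

Compound 3, `O=C1N[C@H]2[C@H](CS[C@H]2CCCCCc2cn(Cc3ccccc3Br)nn2)N1`: compound 3 gives > 16000 nM, also a limit of the assay.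

Compound 3 thus stands at the limit, as the limit of > 16000 nM in this assay, at which 3 of the 3 values shown sit, records: every value shown sits there, and none of the three compounds can be placed above or below another. The steps between them are accordingly unreadable: a step that the two limits leave unreadable from compound 1 to compound 2, a step that the two limits leave unreadable from compound 1 to compound 3 and a step that the two limits leave unreadable from compound 2 to compound 3.

Compound 4, `O=C1N[C@H]2[C@H](CS[C@H]2CCCCCc2cn(Cc3ccc(F)cc3)nn2)N1`, differs from compound 3 in that (4-fluorophenyl in place of 2-bromophenyl on a saturated chain carbon bound to an aromatic nitrogen). The measured steps that bear on this change are the two that exchange the aryl group on the same chain carbon, ending at compound 3; both are unreadable, so they fix neither a size nor a direction, and nothing among the values shown suggests that a further exchange of the aryl group would move the value off the limit. Compound 4 is therefore expected to stay at the limit as well, with a step that the limit leaves unreadable from compound 3 to compound 4 expected to be no readable step. The estimate for compound 4 is 30000 nM, with a range from 8000 nM to 120000 nM.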

Compound 4, inhibition constant: > 16000 nM
Compound 4 ended at the assay's limit; the forecaster's own chance of this, stated with the estimate: 80%; the middle value does not contradict the limit.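

In this assay compound 4 gives > 16000 nM, which is a limit of the assay and not a number. Among these compounds, no step among compound 1, compound 2, compound 3 and compound 4 can be read, because all of them sit at the same limit: the limit of > 16000 nM in this assay, at which 4 of the 4 values shown sit. The compounds shown leave open how strongly any of them inhibits the protein, and whether any benzyl group on the shared core would bring a value off the limit.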